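Replacing a Nitrile with a Methyl Group: Expectations

A few compounds are considered here, and "the series" means these few. Any claim that something is new, unique, unknown or untested is made for them only; others in the source may bear on it.

Of the compounds shown here, three have been measured so far in a physicochemical assay, with a stated time of 50 min; on this read-out higher numbers stand for weaker inhibition and lower numbers for stronger inhibition. Compound 1 `O=C(O)[C@@H]1CSC(c2cccc(F)c2F)N1` gives 46800 nM in this assay. Compound 2 `O=C(O)[C@@H]1CSC(c2c(F)cccc2F)N1` gives 38300 nM. Compound 3 `N#Cc1ccccc1C1N[C@H](C(=O)O)CS1` differs from both in carrying a cyano group on its aromatic ring; for compound 3 this assay returns only a limit, > 1000000 nM, so no number is known for it. On the values shown, compound 3 therefore stands at the limit of > 1000000 nM in this assay, at which 1 of the 3 values shown sits, while compound 1 and compound 2 each have a measured number.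

Compound 4 `Cc1ccccc1C1N[C@H](C(=O)O)CS1` has not yet been measured. It differs from compound 3 in one place: methyl in place of cyano on an aromatic carbon. Among the compounds with values here, no step between measured compounds is available to guide this change, since compound 3 has only a limit. The fluorine-bearing analogues have measured numbers, compound 1 at 46800 nM and compound 2 at 38300 nM, which shows that the shared core can reach measurable inhibition. The replacement is expected to bring compound 4 back into the measurable range, and the expected step is an at least 3.3-fold lower number from compound 3 to compound 4 (0.52 log units; beyond the scatter) toward stronger inhibition, though a limit remains a real possibility. Compound 4 is therefore estimated at 300000 nM, with a range from 60000 nM to 1500000 nM.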

Compound 4, half-maximal inhibitory concentration: 39000 nM
Compound 4: middle estimate off by 7.7-fold (0.89 log units), on the high side, outside the stated range (below it).
By their numbers in this assay, from the lowest: compounds 2, 4 and 1 (each within the scatter of the next). At a limit, above all of these: compound 3.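

In this assay, putting methyl in place of cyano on this aromatic carbon gives an at least 25-fold lower number from compound 3 to compound 4 (1.40 log units; beyond the scatter), so a change at this one place is enough to separate a compound with only a limit from one with a measured number. The earlier compounds shown here could not show this, as they offered no step between measured compounds that differ in one place, and nothing in them tied the missing number of compound 3 to its cyano group. The true size of the step stays unknown, because compound 3 sits at a limit of the assay and not at a number: the limit of > 1000000 nM in this assay, at which 1 of the 4 values shown sits.

The step swaps one group for another, so it cannot tell whether the gain comes from losing the cyano group or from gaining the methyl group, and a plain hydrogen, a chlorine atom, a methoxy group or an amine on the same carbon would help to separate the two. It is also a single pair at a single place, so it leaves open whether a cyano group elsewhere on the aromatic ring would behave the same way.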